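A Ring Loses Its Double Bond

A few compounds are considered here, and "the series" means these few. Any claim that something is new, unique, unknown or untested is made for them only; others in the source may bear on it.

Compound 1 (`CC(C)CN(C)Cc1ccc(C2=CCCN(C)C2)cc1`) has the entry "not determined" (no result reported) in a functional assay on HL-60 cells (Homo sapiens) for inhibition (on this read-out lower numbers stand for stronger inhibition and higher numbers for weaker inhibition), and so offers no number. Among the compounds with values here, compound 2 (`CN1CCC=C(c2ccc(CN(C)C/C=C/c3ccccc3)cc2)C1`) gives 680 nM in this assay and is the only compound with a number so far. Compound 3 (`CN(C/C=C/c1ccccc1)Cc1ccc(C2CCCN(C)C2)cc1`) is still unmeasured. Its change from compound 2 is a group of 7 heavy atoms (6 carbon, 1 nitrogen; one six-membered non-aromatic ring with 1 hetero atom) in place of a group of 7 heavy atoms (6 carbon, 1 nitrogen; one six-membered non-aromatic ring with 1 hetero atom), on an aromatic carbon on an aromatic carbon of a six-membered aromatic ring of carbon only, with 1-methylpiperidin-3-yl entering. Within the data shown here, no measured step guides the size, so the expected change a 1.2-fold higher number from compound 2 to compound 3 (0.07 log units; within the scatter) is none beyond the usual scatter of this assay in either direction. Compound 3 is estimated at 800 nM with 250 nM to 2500 nM as its likely range.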

Compound 3, half-maximal inhibitory concentration: 1100 nM
Beside the measured number, compound 3's estimate is 1.4-fold (0.14 log units) below it, within the range that was stated.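

In this assay, putting 1-methylpiperidin-3-yl in place of the ring with the double bond, on the aromatic carbon para to a large group, gives a 1.6-fold higher number from compound 2 to compound 3 (0.21 log units; within the scatter). At this position, then, the ring's double bond can be removed without a shift that stands out from the usual scatter. Nothing shown explains this result. On these data alone, what remains open is how much this position tolerates a different group, such as a carboxylic acid or an open-chain amine, in place of the ring.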